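The source may hold more compounds than are shown below. What is called first, only, known or untested is meant among the compounds shown, and "the series" means these compounds.

Measured compounds in a functional assay on MKN-45 cells (Homo sapiens) for cytotoxicity; a higher number here means a weaker inhibitor, a lower number a stronger inhibitor:
compound 1 `COc1ccc(S(=O)(=O)N2CCc3cccc(NS(=O)(=O)c4ccc(F)cc4)c32)cc1`: 890 nM
compound 2 `COc1ccc(S(=O)(=O)N2CCc3cccc(NC(C)=O)c32)cc1`: 61 nM
compound 3 `COc1ccc(S(=O)(=O)N2CCc3cccc(NC(=O)c4ccco4)c32)cc1`: 10.7 nM

Compound 1 stands at the highest number of the three, so it is the weakest of this small set in this assay; compound 2 lies nearest to it and compound 3 furthest from it. Between compounds 2 and 3 the gap is a 5.7-fold lower number from compound 2 to compound 3 (0.76 log units; beyond the scatter).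

Compound 4 `COc1ccc(S(=O)(=O)N2CCc3cccc(NC(=O)c4ccc(C#N)cc4)c32)cc1` has not yet been measured in this assay. Against compound 1 the change is (4-cyanophenyl)carbonyl in place of (4-fluorophenyl)sulfonyl on a nitrogen on an aromatic ring.

For the measured compounds named here, two measured steps bear directly on this one, since both start from compound 1 and both replace the (4-fluorophenyl)sulfonyl on the nitrogen with a carbonyl-linked group: a 15-fold lower number from compound 1 to compound 2 (1.16 log units; beyond the scatter) and an 83-fold lower number from compound 1 to compound 3 (1.92 log units; beyond the scatter). Both are large and both run downward. The step to compound 4 is of the same type, with (4-cyanophenyl)carbonyl entering, so a large downward step in this assay, well beyond the scatter, is expected, estimated as a 59-fold lower number from compound 1 to compound 4 (1.77 log units; beyond the scatter). Going by the values given here, of the two precedents, compound 3, which also carries a ring on the carbonyl carbon, is the closer analogy, though with only three numbers the landing point between compound 2 and compound 3 is uncertain. Compound 4 is therefore estimated at 15 nM, within 4 nM to 60 nM.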

Compound 4, half-maximal inhibitory concentration: 89 nM
Compound 4: middle estimate off by 5.9-fold (0.77 log units), on the low side; measured number above the stated range.
By their numbers in this assay, from the lowest: compound 3; then compounds 2 and 4 (each within the scatter of the next); then compound 1.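

In this assay there is an 8.3-fold higher number from compound 3 to compound 4 (0.92 log units; beyond the scatter) with 4-cyanophenyl in place of furan-2-yl on the carbonyl carbon, so a ring at this place does not in itself give the low number of compound 3, and the identity of the ring matters. The change away from the sulfonyl still gives a 10-fold lower number from compound 1 to compound 4 (1.00 log units; beyond the scatter) even though (4-cyanophenyl)carbonyl keeps the same heavy-atom count and the same type of six-membered aromatic ring as (4-fluorophenyl)sulfonyl, so the lower number seen on leaving the sulfonyl does not depend on losing that ring or shrinking the group. With a 1.5-fold higher number from compound 2 to compound 4 (0.16 log units; within the scatter) on the carbonyl carbon, 4-cyanophenyl and methyl cannot be told apart here, which leaves compound 3 alone among the amides in standing clear of the others.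

An unsubstituted phenyl, a 4-fluorophenyl or a thiophene ring on the carbonyl carbon would show whether the gap from compound 3 follows the ring itself or the nitrile on it, and a (furan-2-yl)sulfonyl on the nitrogen would test the sulfonyl with the better ring. No measurement on hand accounts for any of these differences.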